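Chloro Substituents on a Pyridazinone Series Measured in Glioma Cells

The compounds below may be only part of what the source reports. "The series", "measured", "known", "first", "only" and "open" are said of these compounds alone.

The measured compounds are:
compound 1 `COc1cc2c(Oc3ccc(NC(=O)c4nn(-c5ccccc5)c(=O)cc4C)cc3F)ccnc2cc1OCCCN1CCCC1`, 1100 nM;
compound 2 `COc1cc2c(Oc3ccc(NC(=O)c4nn(-c5ccc(Cl)cc5)c(=O)cc4C)cc3F)ccnc2cc1OCCCN1CCCC1`, 1430 nM;
compound 3 `COc1cc2c(Oc3ccc(NC(=O)c4nn(-c5ccc(Cl)cc5)c(=O)cc4C)cc3F)ccnc2cc1OCCCN1CCCCC1`, 1400 nM.

All three were tested in a functional assay on U-87MG ATCC cells (Homo sapiens) for inhibition, read by MTT assay, with a stated time of 72 h; on this read-out higher numbers stand for weaker inhibition and lower numbers for stronger inhibition. Compound 1 gives 1100 nM there, and compound 2 gives 1430 nM. The two differ by chloro in place of hydrogen on an aromatic carbon, placed para to a large group, and that step was a 1.3-fold higher number from compound 1 to compound 2 (0.11 log units; within the scatter). Compound 3 gives 1400 nM in this assay; its step from compound 2 was a 1.0-fold lower number from compound 2 to compound 3 (0.01 log units; within the scatter). The difference between the cores of compound 1 and compound 3 is not broken down here.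

Compound 4 `COc1cc2c(Oc3ccc(NC(=O)c4nn(-c5ccc(Cl)cc5Cl)c(=O)cc4C)cc3F)ccnc2cc1OCCCN1CCCCC1` has not yet been measured. It differs from compound 3 by chloro in place of hydrogen on an aromatic carbon. Among the measured compounds shown here, this is the same kind of change as the one from compound 1 to compound 2, but the place is not the same: here the entering chloro sits ortho to a large group and meta to a chloro group, whereas in the earlier case it sat para to a large group. Because the earlier step was a 1.3-fold higher number from compound 1 to compound 2 (0.11 log units; within the scatter), a step of a similar size is expected here, and compound 4 is estimated to show a 1.2-fold higher number from compound 3 to compound 4 (0.08 log units; within the scatter) in this assay. The estimate for compound 4 is 1700 nM, expected to lie between 800 nM and 3600 nM, resting only on the small step seen from compound 1 to compound 2 and on the value of compound 3 1400 nM.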

Compound 4, half-maximal inhibitory concentration: 1800 nM
Compound 4: middle estimate off by 1.1-fold (0.02 log units), on the low side; the range from low to high includes it.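

In this assay, the step to the 2,4-dichlorophenyl group gave a 1.3-fold higher number from compound 3 to compound 4 (0.11 log units; within the scatter), so compound 4 stays within the scatter of compound 3 in these cells. Among the compounds shown here, this does not show that the chloro change has no effect on every core, since it rests on only two pairs, one carrying pyrrolidin-1-yl and the other piperidin-1-yl on the chain, and the chloro enters at a different place on the aromatic ring in each pair; core and place therefore cannot be told apart here, and neither step can be read as a real change in inhibition. What the two pairs do show is that the step read about the same on both cores:
the same change on two cores in this assay, a 1.3-fold higher number (0.11 log units; within the scatter) from compound 1 to compound 2 and a 1.3-fold higher number (0.11 log units; within the scatter) from compound 3 to compound 4, 1.0-fold (0.00 log units) apart, within the scatter of two such steps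

The compounds shown leave open whether a fluoro, methoxy or trifluoromethyl group on the same aromatic ring would also stay within the scatter of its parent compound. They also leave open whether a morpholine or a dimethylamino group at the end of the chain, or a longer chain, would keep the values close to those seen for the pyrrolidin-1-yl and piperidin-1-yl compounds.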